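The source may report more compounds than this note shows. Statements on the series, on what has been measured and on what is new or still open speak of the compounds shown alone.

Compound 1 `Cc1cc(NC(=S)Cn2nnc(-c3ccccc3)n2)n(C2CCCCC2)n1`: in an assay on HEK293 cells for activation of Kir3.1/Kir3.2 (Homo sapiens), read by thallium flux (a lower number here means a smaller maximal response, a higher number a larger maximal response), compound 1 gives 80%.
Compound 2 `CC1CC1c1cc(NC(=O)Cn2nnc(-c3ccccc3)n2)n(C2CCCCC2)n1`: in this assay compound 2 gives 78%.
Compound 3 `Cc1cc(NC(=O)Cn2nnc(-c3cccnc3)n2)n(C2CCCCC2)n1`: in this assay compound 3 gives 96%.

Compound 3 stands highest of the three numbers. Its gap to compound 1, the nearest, and its gap to compound 2, the furthest, both lie beyond the usual scatter. No two of the measured compounds differ in one place only, so none of these gaps can be tied to a single structural change.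

Compound 4 `Cc1cc(NC(=O)Cn2nnc(-c3ccc(F)c(F)c3)n2)n(C2CCCCC2)n1` has not yet been measured. Relative to compound 3 the change is 3,4-difluorophenyl in place of pyridin-3-yl on an aromatic carbon. The two measured compounds that carry a six-membered aromatic ring of carbon only at the same place, compound 1 and compound 2, both sit below compound 3, but each also differs from compound 3 elsewhere, so what this change alone does is not settled. A downward step beyond the scatter is expected in this assay, a number 14 percentage points lower from compound 3 to compound 4 (beyond the scatter). Compound 4 is estimated at 82%, with a range from 65% to 100%.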

Compound 4, largest response reached (Emax), in percent of the reference or control that the assay uses: 93%
For compound 4 the middle estimate is 11 percentage points below the measured one; low and high end bracket the measured number.
By their numbers in this assay, from the lowest: compounds 2 and 1 (each within the scatter of the next); then compounds 4 and 3 (each within the scatter of the next).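

Going by these compounds alone, on the aromatic carbon of the five-membered aromatic ring with 4 nitrogen, 3,4-difluorophenyl in place of pyridin-3-yl gives, in this assay, a number 3 percentage points lower from compound 3 to compound 4 (within the scatter), the first step that can be tied to one change. At this place, a six-membered aromatic ring of carbon only, without the ring nitrogen and its hydrogen-bond acceptor, therefore leaves the largest response within the scatter, so that ring nitrogen is not needed to keep it. No measured evidence on the compounds bears on this result.

Going by these compounds, whether a non-aromatic group at the same place, such as an amine or a carboxylic acid on a short chain, would keep the response remains open. On these data alone, the separate contributions of the thiocarbonyl in compound 1 and the methylcyclopropyl group in compound 2 also remain open.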